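Swapping the Pyrazole on an Amide Nitrogen

This account rests on a few compounds, and the source may have more. Where it says the series, first, only, none or still open, it means among the compounds named here.

Of the compounds shown here, three have been tested in an assay on HEK293 cells for agonist activity at transient receptor potential cation channel subfamily M member 8 (Homo sapiens), read by fluorescence and calcium flux, with a stated time of 15 min; on this read-out higher numbers stand for an effect only at larger amounts of compound and lower numbers for an effect already at smaller amounts. Compound 1 `Cc1ccc(OCC(=O)N(Cc2cccs2)c2ccnn2C)cc1` gives 422 nM. Compound 2 `CCN(Cc1ccsc1)C(=O)COc1ccc(C)cc1` gives 88 nM, and compound 3 `CCN(Cc1cccs1)C(=O)C(C)(C)Oc1ccc(C)cc1` gives 11000 nM. Among these three numbers, compound 1 stands second highest: its nearest neighbour is compound 2, whose lower number lies beyond the scatter, and its furthest is compound 3, whose higher number also lies beyond the scatter. Compounds 2 and 3 each differ from compound 1 in more than one place, so their values show only the spread of the series, not the effect of any single change.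

Compound 4 `Cc1ccc(OCC(=O)N(Cc2cccs2)c2cn[nH]c2)cc1` has not been measured yet. It differs from compound 1 in one place: 1H-pyrazol-4-yl in place of 1-methyl-1H-pyrazol-5-yl on an amide-type nitrogen. Among the compounds with values here, no pair of measured compounds differing only here is known, so the size of the step must be estimated. A modest step towards a higher number is expected, a 1.5-fold higher number from compound 1 to compound 4 (0.19 log units; within the scatter), though it may well stay within the scatter. Compound 4 is therefore expected to give about 650 nM in this assay, within a range from 150 nM to 2800 nM.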

Compound 4, half-maximal effective concentration: 1.4 nM
Beside the measured number, compound 4's estimate is 460-fold (2.67 log units) above it; measured number outside the range, below it.
By their numbers in this assay, from the lowest: compound 4; then compound 2; then compound 1; then compound 3.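

Within the data shown here, the group on the amide-type nitrogen turns out to matter far more than the earlier compounds could show: in this assay, 1H-pyrazol-4-yl in place of 1-methyl-1H-pyrazol-5-yl gives a 300-fold lower number from compound 1 to compound 4 (2.48 log units; beyond the scatter), a large step beyond the scatter. Both groups are five-membered aromatic rings with 2 hetero atoms, yet the entering group has 1 hydrogen-bond donor where the leaving group has 0, so a small edit to the ring can change the result greatly. Nothing available explains why this step is so large.

The compounds shown leave open which part of the change matters, since the methyl group and the point of attachment both differ. A 1-methyl-1H-pyrazol-4-yl group on the same nitrogen would help separate these two differences.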